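Swapping amino for fluoro in compound 2

This account rests on a few compounds, and the source may have more. Where it says the series, first, only, none or still open, it means among the compounds named here.

Going by the values given here, compound 2, `Nc1cccc(-c2cn(CC(=O)NCc3ccccc3)nn2)c1`, gives 800 uM in an ADME assay on cells (spleen, Mus musculus, strain C57BL/6) for inhibition, read by flow cytometry and propidium iodide staining, with a stated time of 24 h, at 37 degrees C (a lower number here means that less compound is needed, a higher number that more compound is needed for the effect), and this is the only true number so far. Compound 1, `NCc1cn(CC(=O)NCc2ccccc2)nn1`, gives > 2000 uM in this assay, which is a limit of the assay and not a number.

Compound 3, `O=C(Cn1cc(-c2cccc(F)c2)nn1)NCc1ccccc1`, departs from compound 2 by a single exchange, fluoro in place of amino on an aromatic carbon.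

Among the compounds with values here, only one measured step is available, an at least 2.5-fold lower number from compound 1 to compound 2 (0.39 log units; beyond the scatter). That step is a bound and not a measured size, resting on (the limit of > 2000 uM in this assay, at which 1 of the 2 values shown sits). It bears only indirectly on the new change, since it concerns a different exchange. Compound 1 and compound 2 both carry an amino group, so the data hold no case of its loss and give no direction for this exchange.

The step expected is therefore no change at the digits printed from compound 2 to compound 3 (within the scatter), with no shift beyond the scatter anticipated in this assay. The estimate for compound 3 is 800 uM, with an expected range from 300 uM to 2000 uM.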

Compound 3, concentration for half-maximal effect: "non-toxic" (no number reported)
No number was reported for compound 3; no gap can be computed for the estimate.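

Going by these compounds alone, compound 3 is reported in this assay only as "non-toxic" (no number reported), without a number, so no step from compound 2 to compound 3 can be read. The compounds shown leave open whether fluoro in place of amino on the aromatic carbon shifts the result in this assay beyond the scatter, and in which direction.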